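The source may report more compounds than this note shows. Statements on the series, on what has been measured and on what is new or still open speak of the compounds shown alone.

Working notes on the series. Two analogues of the shared core have numbers in an ADME assay on HeLa cells (Homo sapiens) for cytotoxicity, read by sulforhodamine B assay, with a stated time of 48 h, tested at 10 uM; on this read-out higher numbers stand for more inhibition at the one concentration tested (going by the name of the read-out) and lower numbers for less inhibition. Compound 1 `COc1nc2ccc(Br)cc2cc1C(c1ccccc1)n1cc(-c2ccccc2)nn1` gives 13.9%. Compound 2 `COc1nc2ccc(Br)cc2cc1C(c1ccccc1)n1cc(CCCO)nn1` gives 11.3%, and on the numbers shown compound 2 stands with compound 1 as its only neighbour, the gap between the two within the usual scatter; the single measured step is a number 2.6 percentage points lower from compound 1 to compound 2 (within the scatter).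

Compound 3 `COc1nc2ccc(Br)cc2cc1C(c1ccccc1)n1cc(-c2ccccc2C(F)(F)F)nn1` is not yet measured. Its change from compound 2 is 2-(trifluoromethyl)phenyl in place of 3-hydroxypropyl on an aromatic carbon. For the measured compounds named here, the only step that bears on this is a number 2.6 percentage points lower from compound 1 to compound 2 (within the scatter), which runs the exchange between 3-hydroxypropyl and an aryl group in the opposite direction and stayed within the scatter. No step beyond the scatter is therefore expected in this assay for compound 3, in either direction; the expected step is a number 2.7 percentage points higher from compound 2 to compound 3 (within the scatter). Compound 3 is estimated at 14%, with a range from 4% to 26%.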

Compound 3, a percentage reported as inhibition, at one concentration (the size of the read-out at that concentration, not a potency): -1.3%
The estimate for compound 3 lay 15.3 percentage points above the measured number; the measured number lies below the stated range.
By their numbers in this assay, from the lowest: compound 3; then compounds 2 and 1 (each within the scatter of the next).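

This position does respond in this assay: 2-(trifluoromethyl)phenyl in place of 3-hydroxypropyl gives a number 12.6 percentage points lower from compound 2 to compound 3 (beyond the scatter) and so exceeds the scatter, which the exchange between phenyl and 3-hydroxypropyl did not. Trifluoromethyl in place of hydrogen on the phenyl group gives a number 15.2 percentage points lower from compound 1 to compound 3 (beyond the scatter) as well, so the drop goes with this added group and not with the presence of an aryl group as such, compound 1 being the aryl compound that goes against any rule on aryl groups alone. Nothing available on these compounds explains the drop.

From the compounds shown here alone, it remains open whether a smaller group such as fluorine or methyl on the phenyl group would give a similar step. Going by these compounds, the effect of an amine or a carboxylic acid in place of the hydroxyl of the 3-hydroxypropyl group is also open.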